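A few compounds are considered here, and "the series" means these few. Any claim that something is new, unique, unknown or untested is made for them only; others in the source may bear on it.

Measured so far in an ADME assay on Vero cells (Chlorocebus sabaeus) for cytotoxicity, read by MTT assay, with a stated time of 48 h; on this read-out lower numbers stand for stronger inhibition and higher numbers for weaker inhibition:
- compound 1 `O=c1cc(N2CCN(CC3CCC(OS(=O)(=O)c4cccnc4)CC3)CC2)sc2c([N+](=O)[O-])cc(C(F)(F)F)cc12`: > 64 ug/mL
- compound 2 `CS(=O)(=O)OC1CCC(CN2CCN(c3cc(=O)c4cc(C(F)(F)F)cc([N+](=O)[O-])c4s3)CC2)CC1`: > 64 ug/mL
- compound 3 `CC(C)C(=O)OC1CCC(CN2CCN(c3cc(=O)c4cc(C(F)(F)F)cc([N+](=O)[O-])c4s3)CC2)CC1`: > 64 ug/mL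

Each of these entries is a limit of the assay and not a number. Compound 2 therefore has no exact position, and its entry of > 64 ug/mL is only a limit. The series as a whole offers (the limit of > 64 ug/mL in this assay, at which 3 of the 3 values shown sit), so no ranking can be drawn from it.

Compound 4 `CCCC(=O)OC1CCC(CN2CCN(c3cc(=O)c4cc(C(F)(F)F)cc([N+](=O)[O-])c4s3)CC2)CC1` differs from compound 2 at one place: propylcarbonyl in place of methylsulfonyl on an oxygen on a saturated carbon. In words, propylcarbonyl stands in place of methylsulfonyl on an oxygen on a saturated carbon.

Among the compounds with values here, three measured steps bear on this change. The closest is a step that the two limits leave unreadable from compound 2 to compound 3, which replaces the same methylsulfonyl with isopropylcarbonyl. The other two are a step that the two limits leave unreadable from compound 1 to compound 2 and a step that the two limits leave unreadable from compound 1 to compound 3. None of them has a readable size, so none gives a direction. In this assay, no step beyond the scatter is therefore expected for this change, and compound 4 may well also be reported only as a limit. The estimated change is a step that the limit leaves unreadable from compound 2 to compound 4. For compound 4 the expected value is 80 ug/mL, with an estimated range from 45 ug/mL to 150 ug/mL.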

Compound 4, half-maximal inhibitory concentration: > 64 ug/mL
Compound 4 ended at the assay's limit; the forecaster's own chance of this, stated with the estimate: 85%; the middle value is on the limit's open side.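

In this assay compound 4 gives > 64 ug/mL, which is a limit of the assay and not a number. No new step can be read from compound 4 to compound 1, compound 2 or compound 3. The compounds shown leave open how these groups on the oxygen rank, because every value sits at one limit: the limit of > 64 ug/mL in this assay, at which 4 of the 4 values shown sit.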